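This account rests on a few compounds, and the source may have more. Where it says the series, first, only, none or still open, it means among the compounds named here.

For the measured compounds named here, in a functional assay on T47D cells (Homo sapiens) for cytotoxicity, read by sulforhodamine B assay, with a stated time of 48 h, tested at 1 uM (a lower number here means a stronger effect, a higher number a weaker effect of the compound at the concentration tested), compound 1 `COc1cc(-c2cc(/C=C/C(=O)c3ccc(N)cc3)[nH]n2)cc(OC)c1OC` gives 66% and compound 2 `COc1ccc(C(=O)/C=C/c2cc(-c3cc(OC)c(OC)c(OC)c3)n[nH]2)cc1OC` gives 75%; the single step so far, a number 9 percentage points higher from compound 1 to compound 2 (within the scatter), stays within the scatter. Compound 2 thus holds the higher of the two numbers, with compound 1 nearest and not separated from it beyond the scatter. Compound 3 `COc1cc(-c2cc(/C=C/C(=O)c3ccc(F)c(F)c3)[nH]n2)cc(OC)c1OC` carries 3,4-difluorophenyl in place of 3,4-dimethoxyphenyl on a carbonyl carbon. Going by the values given here, the one step that bears on this, an aryl exchange on the same carbonyl carbon, was a number 9 percentage points higher from compound 1 to compound 2 (within the scatter), so no step beyond the scatter is expected for compound 3 in this assay, estimated as a number 5 percentage points lower from compound 2 to compound 3 (within the scatter). Compound 3 is estimated at 70%, between 50% and 90%.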

Compound 3, a percentage reported as activity, at one concentration (the size of the read-out at that concentration, not a potency): 76%
Compound 3: the middle estimate sits 6 percentage points below what was measured; measured number inside the range.
By their numbers in this assay, from the lowest: compounds 1, 2 and 3 (each within the scatter of the next).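

In this assay the 3,4-difluorophenyl group gives a number 1 percentage points higher from compound 2 to compound 3 (within the scatter) and a number 10 percentage points higher from compound 1 to compound 3 (within the scatter) on this carbonyl carbon. All three aryl groups at this position therefore stay within the scatter of one another, even though the group entering here has 0 hydrogen-bond acceptors and the 3,4-dimethoxyphenyl it replaces has 2. Nothing measured on these compounds speaks to why the aryl exchanges leave the read-out inside the scatter. Open, on these data alone, is whether a carboxylic acid, a dimethylamino group or an unsubstituted phenyl on this carbonyl carbon would read apart from these three compounds.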